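This account rests on a few compounds, and the source may have more. Where it says the series, first, only, none or still open, it means among the compounds named here.

For the measured compounds named here, compound 2 `COc1ccc(Sc2nc3cc(N)cc(N)c3nc2-c2ccccc2)cc1` is the only compound here with a number in a functional assay on CCRF-CEM cells (Homo sapiens) for inhibition, read by sulforhodamine B assay, with a stated time of 48 h; a higher number here means a weaker inhibitor of growth, a lower number a stronger inhibitor of growth: compound 2 gives 8320 nM. Compound 1 `Nc1cc(N)c2nc(-c3ccccc3)c(Oc3ccc(Cl)c(Cl)c3)nc2c1` shows only a limit in this assay, compound 1 giving < 100000 nM. The step that the limit leaves unreadable from compound 1 to compound 2 therefore cannot be sized, because of the limit of < 100000 nM in this assay, at which 1 of the 2 values shown sits. Compound 3 `Nc1cc(N)c2nc(-c3ccccc3)c(Sc3ccc(Cl)c(Cl)c3)nc2c1` differs from compound 2 by 3,4-dichlorophenyl in place of 4-methoxyphenyl on a sulfur. Going by the values given here, no measured step isolates this change, so no direction beyond the scatter is expected, and the estimated step of a 1.0-fold lower number from compound 2 to compound 3 (0.02 log units; within the scatter) is flat. Compound 3 is thus estimated at 8000 nM, between 2500 nM and 25000 nM in this assay.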

Compound 3, concentration for total growth inhibition: < 100000 nM
Compound 3 gave a limit, no number (the forecaster's own chance of this, stated with the estimate: 5%); the middle value does not contradict the limit.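

The steps linking compound 3 with compound 2 and with compound 1 cannot be read, because they rest on a limit: the limit of < 100000 nM in this assay, at which 2 of the 3 values shown sit.

What the compounds shown leave open is how 3,4-dichlorophenyl in place of 4-methoxyphenyl, or (3,4-dichlorophenyl)sulfanyl in place of 3,4-dichlorophenoxy, shifts the number in this assay.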